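This account rests on a few compounds, and the source may have more. Where it says the series, first, only, none or still open, it means among the compounds named here.

Measured in an ADME assay on HEK293 cells (Homo sapiens) for cytotoxicity, read by CellTiter-Glo and resazurin assay, with a stated time of 72 h; a higher number here means that more compound is needed for the effect, a lower number that less compound is needed:

Compound 1, `CCOC(=O)CCCCCOc1cccc(CN(C(=O)c2ccc(-c3ccc4ccccc4c3)cc2)C(C)C)c1`, gives > 26000 nM, which is a limit of the assay.
Compound 2, `CCOC(=O)CCCCCOc1cccc(CN(C(=O)c2ccc(-c3cccc(C(C)=O)c3)cc2)C(C)C)c1`, gives > 26000 nM, which is also a limit.
Compound 3, `CCOC(=O)CCCCCOc1cccc(CN(C(=O)c2ccc(-c3ccc4[nH]ccc4c3)cc2)C(C)C)c1`, gives > 26000 nM, again a limit.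

The three compounds share one core and differ only in the group exchanged on it. Compound 3 thus stands at the same limit as the other two, and the steps a step that the two limits leave unreadable from compound 1 to compound 2, a step that the two limits leave unreadable from compound 1 to compound 3 and a step that the two limits leave unreadable from compound 2 to compound 3 cannot be given a size because of the limit of > 26000 nM in this assay, at which 3 of the 3 values shown sit. Compound 4, `CCOC(=O)CCCCCOc1cccc(CN(C(=O)c2ccc(-c3cccc(OCC)c3)cc2)C(C)C)c1`, is not yet measured. It differs from compound 3 in one place: 3-ethoxyphenyl in place of 1H-indol-5-yl on an aromatic carbon. Every exchange of this group seen so far has left the read-out at the limit, so for compound 4 no step beyond the scatter is expected in this assay, and the expected step that the limit leaves unreadable from compound 3 to compound 4 is taken as small. Compound 4 is therefore estimated at 40000 nM, in a range from 15000 nM to 150000 nM, most likely reported once more as a limit.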

Compound 4, half-maximal effective concentration: > 22300 nM
Compound 4 was reported as a limit; the forecaster's own chance of this, stated with the estimate: 85%; the middle value does not contradict the limit.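

Compound 4, like compound 1, compound 2 and compound 3, gives only a limit in this assay, so no step between any of these compounds can be read. The compounds shown leave open how much of each is needed for the effect, and whether exchanging this group changes that amount at all.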